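The source may hold more compounds than are shown below. What is called first, only, known or untested is meant among the compounds shown, and "the series" means these compounds.

Measured so far:
- compound 1 `COc1cc(/C=C/C(=O)c2cccc(-n3cc(-c4ccccc4)[nH]c3=O)c2)ccc1O`: 2040 nM
- compound 2 `COc1cc(/C=C/C(=O)c2cccc(-n3cc(-c4ccccc4)[nH]c3=O)c2)cc(OC)c1OC`: 500 nM

In a functional assay on K562 cells (Homo sapiens) for inhibition (a higher number here means a weaker inhibitor of growth, a lower number a stronger inhibitor of growth), compound 1 gives 2040 nM, the highest of the two numbers recorded. Compound 2 gives 500 nM, a lower number that lies beyond the usual scatter, so compound 2 is the stronger inhibitor of growth of the two; the two structures differ in more than one place, and the numbers alone are what is known of that pair.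

Compound 3 `COc1cc(/C=C/C(=O)c2cccc(-n3cc(-c4ccc(Cl)cc4)[nH]c3=O)c2)ccc1O` differs from compound 1 by chloro in place of hydrogen on an aromatic carbon. Among the measured compounds shown here, no measured pair shows this change, so there is no step to lean on, and the expectation rests on compound 1 alone. A step of this kind is expected to be small, if anything towards a slightly lower number, and not clearly beyond the scatter. The step of a 1.4-fold lower number from compound 1 to compound 3 (0.13 log units; within the scatter) is therefore expected to be modest. Compound 3 is estimated at 1500 nM, within a range from 600 nM to 4000 nM.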

Compound 3, concentration for 50% growth inhibition: 1420 nM
The estimate for compound 3 lay 1.1-fold (0.02 log units) above the measured number; measured number inside the range.
By their numbers in this assay, from the lowest: compound 2; then compounds 3 and 1 (each within the scatter of the next).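

Phenyl to 4-chlorophenyl gives the first comparison in this series that differs in one place only, and in this assay it reads a 1.4-fold lower number from compound 1 to compound 3 (0.16 log units; within the scatter). Chloro in place of hydrogen at this position, para to a large group, therefore leaves the growth-inhibition read-out of compound 1 indistinguishable from that of compound 3, so the position accepts this one heavy atom on the background of compound 1. Nothing measured here gives a reason for this outcome or ties it to any property of the chloro group.

Going by these compounds, whether chloro would read the same way on the more heavily methoxylated core of compound 2 remains open. Also open, on these data alone, is how a larger or differently built group at this position, such as an amine, a carboxylic acid or a longer chain, would read in this assay.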